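5-HT1D binding series: urea-to-amine replacement on the side chain

The compounds below may be only part of what the source reports. "The series", "measured", "known", "first", "only" and "open" are said of these compounds alone.

Measured compounds:
compound 1, `CN(CC1CCN(CCCc2c[nH]c3ccc(-n4cnnc4)cc23)CC1)C(=O)Nc1ccccc1`: 5.9 nM
compound 2, `CN(C1CCN(CCCc2c[nH]c3ccc(-n4cnnc4)cc23)CC1)S(=O)(=O)c1ccccc1`: 1.5 nM
compound 3, `CC(=O)Nc1ccc([C@@H](C)NCC2CCN(CCCc3c[nH]c4ccc(-n5cnnc5)cc34)CC2)cc1`: 1.5 nM

In an assay on CHO cells for displacement of a labelled ligand from 5-hydroxytryptamine receptor 1D (Homo sapiens) (on this read-out lower numbers stand for stronger inhibition and higher numbers for weaker inhibition), compound 1 gives 5.9 nM, the highest of the three numbers. Both compound 2 and compound 3 lie below it by a margin beyond the scatter, so compound 1 is the weakest of the measured set.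

Compound 4, `C[C@H](NCC1CCN(CCCc2c[nH]c3ccc(-n4cnnc4)cc23)CC1)c1ccccc1`, has not yet been measured. It differs from compound 1 by (1-phenylethyl)amino in place of methyl(phenylcarbamoyl)amino on a saturated chain carbon bound to a saturated ring carbon. For the measured compounds named here, no measured pair isolates this change. Compound 3 carries the same (1-phenylethyl)amino attachment, with an added acetamido group on the phenyl, and gives 1.5 nM, so a move toward lower numbers seems likely. The step from compound 1 to compound 4 is expected to be a 2.4-fold lower number from compound 1 to compound 4 (0.37 log units; beyond the scatter), toward stronger inhibition. Compound 4 is therefore estimated at 2.5 nM, with a range of 0.8 nM to 8 nM.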

Compound 4, half-maximal inhibitory concentration: 4.4 nM
Estimate against measurement, compound 4: 1.8-fold (0.25 log units) below; the range from low to high includes it.
By their numbers in this assay, from the lowest: compounds 2 and 3 (each within the scatter of the next); then compounds 4 and 1 (each within the scatter of the next).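

In this assay, (1-phenylethyl)amino in place of methyl(phenylcarbamoyl)amino gives a 1.3-fold lower number from compound 1 to compound 4 (0.13 log units; within the scatter), so this change on the saturated chain carbon does not separate the two groups. Without the acetamido group on the phenyl there is a 2.9-fold higher number from compound 3 to compound 4 (0.47 log units; beyond the scatter), and the sulfonyl comparison gives a 2.9-fold higher number from compound 2 to compound 4 (0.47 log units; beyond the scatter), so the (1-phenylethyl)amino attachment alone does not carry the low number of compound 3. Nothing available explains these steps.

Still open, going by these compounds, is whether a different phenyl substituent, such as methoxy or a carboxylic acid, would match the acetamido group. On these data alone, the opposite configuration at the stereocentre of compound 4 also remains open.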